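A few compounds are considered here, and "the series" means these few. Any claim that something is new, unique, unknown or untested is made for them only; others in the source may bear on it.

For the measured compounds named here, compound 1 `CC(C)(CCCCOc1cc(-c2ccccc2)c2ccccc2n1)C(=O)O` holds the higher of the two numbers measured so far: in an assay for binding affinity to leukotriene B4 receptor 1 (Homo sapiens) (on this read-out lower numbers stand for stronger inhibition and higher numbers for weaker inhibition), compound 1 gives 4000 nM, whereas compound 2 `O=C(O)CCCCCOc1cc(-c2ccc(Cl)cc2)c2ccccc2n1` gives 150 nM, a gap well beyond the usual scatter. Compound 3 `Cc1ccc(-c2cc(OCCCCC(C)(C)C(=O)O)nc3ccccc23)cc1` is compound 1 with a single change, methyl in place of hydrogen on an aromatic carbon. Compound 2, which carries both a chlorine and a different chain, shows only that such variations can go with a much lower number. The step of a 2.7-fold lower number from compound 1 to compound 3 (0.43 log units; beyond the scatter) is expected to be a modest gain, just beyond the scatter. Compound 3 is therefore estimated at 1500 nM, with a range from 400 nM to 5000 nM.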

Compound 3, half-maximal inhibitory concentration: 100 nM
Compound 3: middle estimate off by 15-fold (1.18 log units), on the high side; the whole stated range lies above it.
By their numbers in this assay, from the lowest: compounds 3 and 2 (each within the scatter of the next); then compound 1.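

Going from phenyl to 4-methylphenyl, a gain of a single carbon, gives in this assay a 40-fold lower number from compound 1 to compound 3 (1.60 log units; beyond the scatter), so this place on the aromatic ring, para to a large group, strongly affects the read-out. The earlier pair differed in more than one place and could not single out this position. No data shown here explain why so small a change has so large an effect. From the compounds shown here alone, whether an ethyl or a methoxy group at this place would give a similar result remains open.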